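Dropping one methyl from the weaker compound

The compounds below may be only part of what the source reports. "The series", "measured", "known", "first", "only" and "open" are said of these compounds alone.

Compound 1 `COc1ccc2c(c1)CCc1c(-c3ccccc3)c3n(c1-2)[B-](F)(F)[N+]1=C(c2ccc(C)cc2)C(I)=C(c2ccccc2)C1=N3`: 660 nM
Compound 2 `COc1ccc2c(c1)CCc1c(-c3ccccc3)c3n(c1-2)[B-](F)(F)[N+]1=C(c2ccc(C)s2)C(I)=C(c2ccccc2)C1=N3`: 21400 nM

Both values come from a functional assay on SW480 cells (Homo sapiens) for cytotoxicity, read by MTT assay, with stated times of 3 h and 24 h; on this read-out lower numbers stand for stronger inhibition and higher numbers for weaker inhibition. Compound 2 holds the higher of the two numbers, so it is the weaker of this pair. Compound 3 `COc1ccc2c(c1)CCc1c(-c3ccccc3)c3n(c1-2)[B-](F)(F)[N+]1=C(c2cccs2)C(I)=C(c2ccccc2)C1=N3` differs from it in one place: hydrogen in place of methyl on an aromatic carbon. In words, hydrogen replaces methyl on an aromatic carbon, turning 5-methylthiophen-2-yl into thiophen-2-yl.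

Among the compounds with values here, only one measured step bears on this: a 32-fold higher number from compound 1 to compound 2 (1.51 log units; beyond the scatter). Within the data shown here, that large step exchanged a whole group, so it shows that this part of the molecule can matter, but no measured pair isolates the methyl. Compound 1, with 660 nM, shows that much lower numbers are possible, so a smaller, downward step is expected in this assay, though with little certainty. The expected change is a 2.4-fold lower number from compound 2 to compound 3 (0.38 log units; beyond the scatter). The estimate for compound 3 is 9000 nM, with an expected range of 2000 nM to 30000 nM.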

Compound 3, half-maximal inhibitory concentration: 830 nM
Estimate against measurement, compound 3: 11-fold (1.04 log units) above; measured number outside the range, below it.
By their numbers in this assay, from the lowest: compounds 1 and 3 (each within the scatter of the next); then compound 2.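

In this assay there is a 26-fold lower number from compound 2 to compound 3 (1.41 log units; beyond the scatter) when this one methyl leaves, so a single carbon next to the ring sulfur can decide between a weak compound and a strong one. The thiophen-2-yl group itself is compatible with a low number: exchanging 4-methylphenyl for it gives a 1.3-fold higher number from compound 1 to compound 3 (0.10 log units; within the scatter) and leaves the two compounds indistinguishable. The large difference seen earlier between compound 1 and compound 2 therefore goes with the methyl on the five-membered ring, not with the presence of that ring alone.

Nothing measured here explains why so small a change has so large an effect. On these data alone, it also remains open whether only methyl behaves this way at that carbon, or whether a chlorine atom, an ethyl group or an amine there would give a similarly high number.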